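The source may report more compounds than this note shows. Statements on the series, on what has been measured and on what is new or still open speak of the compounds shown alone.

In an assay on HEK293 cells for displacement of a labelled ligand from 5-hydroxytryptamine receptor 7 (Rattus norvegicus) (a higher number here means a weaker inhibitor, a lower number a stronger inhibitor), compound 1 `CSc1ccccc1N1CCN(CCCCCC(=O)N2CCc3ccccc3C2)CC1` gives 32.9 nM, and compound 2 `O=C(CCCCCN1CCN(c2ccccc2-c2ccccc2)CC1)N1CCc2ccccc2C1` gives 3.81 nM. The change between them, (phenyl in place of methylsulfanyl on an aromatic carbon), made an 8.6-fold lower number from compound 1 to compound 2 (0.94 log units; beyond the scatter). Compound 3 `CSc1ccccc1N1CCN(CCCCCC(=O)NCc2ccc(OS(C)(=O)=O)cc2)CC1` carries another core; the difference between the core of compound 3 and the core of compound 1 is not broken down here. In this assay compound 3 gives 148 nM, the highest of the three numbers. Compound 4 `CS(=O)(=O)Oc1ccc(CNC(=O)CCCCCN2CCN(c3ccccc3-c3ccccc3)CC2)cc1` has not yet been measured; it differs from compound 3 by phenyl in place of methylsulfanyl on an aromatic carbon, the same change that turned compound 1 into compound 2, at the same kind of place. For compound 4 a step of similar size is expected, an 8.2-fold lower number from compound 3 to compound 4 (0.91 log units; beyond the scatter), because the earlier step was an 8.6-fold lower number from compound 1 to compound 2 (0.94 log units; beyond the scatter), though this rests on one pair only. Compound 4 is therefore expected to give 18 nM, between 6 nM and 55 nM.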

Compound 4, inhibition constant: 5.7 nM
Estimate against measurement, compound 4: 3.2-fold (0.50 log units) above; measured number below the stated range.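

In this assay phenyl in place of methylsulfanyl lowers the number on both cores, and on the core of compound 3 the step is the larger one (a 26-fold lower number from compound 3 to compound 4 (1.41 log units; beyond the scatter)). For the compounds shown here, with only two pairs, this does not show which part of the cores sets the size of the step, why the size differs, or how the change would fare on a third core. The direction of the change carried from one core to the other, but its size did not carry over unchanged: the same change on two cores in this assay, an 8.6-fold lower number (0.94 log units; beyond the scatter) from compound 1 to compound 2 and a 26-fold lower number (1.41 log units; beyond the scatter) from compound 3 to compound 4, 3.0-fold (0.48 log units) apart, beyond the scatter of two such steps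

The compounds shown leave open whether a methoxy group or a pyridine ring in the place of phenyl would behave alike on both cores. Going by these compounds alone, they also leave open whether the gap between the two steps would persist with a shorter chain in place of the one these compounds share.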